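The compounds below may be only part of what the source reports. "The series", "measured", "known", "first", "only" and "open" are said of these compounds alone.

In an in vitro ADME assay on microsomes from liver (Homo sapiens) for metabolic stability, read by LC-MS, using NADPH, tested at 1 uM (on this read-out lower numbers stand for a shorter-lived compound and higher numbers for a longer-lived compound), two compounds have been measured so far:
- compound 1 `CC(C)CN1C(=O)CN(Cc2ccc(-c3ccc(F)c(CN4CCCC(C)C4)n3)cc2)C1=O` gives 0.1 h 
- compound 2 `O=C1CN(Cc2ccc(-c3ccc(F)c(CN4CCCCC4)n3)cc2)C(=O)N1CC1CC1` gives 0.333 h 

Compound 2 stands highest of these two, and the gap down to compound 1 lies beyond the scatter. Compound 3 `CC(C)CN1C(=O)CN(Cc2ccc(-c3ccc(F)c(CN4CCCCC4)n3)cc2)C1=O` has not yet been measured. It departs from compound 2 in one place, as isopropyl in place of cyclopropyl on a saturated chain carbon bound to an amide-type nitrogen in a ring shows: isopropyl in place of cyclopropyl on a saturated chain carbon bound to an amide-type nitrogen in a ring. Cut one bond further out, the same difference reads cyclopropylmethyl to isobutyl.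

Going by the values given here, no pair of measured compounds isolates this change, so any expectation is loose. Among the compounds with values here, the only guide is that compound 1 also carries the isobutyl group and gives 0.1 h in this assay so a modest fall rather than a rise is expected. The estimated change is a 1.7-fold lower number from compound 2 to compound 3 (0.22 log units; within the scatter) and this expected step toward a shorter half-life would stay within the scatter. For compound 3 the expected half-life is 0.2 h (estimated range 0.09 h to 0.45 h).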

Compound 3, half-life: 0.217 h
Estimate against measurement, compound 3: 1.1-fold (0.04 log units) below, and the stated range covers the measured number.
By their numbers in this assay, from the lowest: compound 1; then compounds 3 and 2 (each within the scatter of the next).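

In this assay, going by these compounds alone, isopropyl in place of cyclopropyl on a saturated chain carbon bound to an amide-type nitrogen in a ring gives a 1.5-fold lower number from compound 2 to compound 3 (0.19 log units; within the scatter), so this change, seen here for the first time on its own, does not separate the two groups at this position. Hydrogen in place of methyl on a saturated ring carbon gives a 2.2-fold higher number from compound 1 to compound 3 (0.34 log units; beyond the scatter), so of the two places in which compound 1 and compound 2 differ, only this one has a step beyond the scatter when taken alone. Nothing available explains either step.

The compounds shown leave open whether the ring methyl would give a similar step with cyclopropylmethyl in place of isobutyl, since only the isobutyl pair isolates it. They also leave open whether a different group on the amide-type nitrogen, such as a longer chain like n-pentyl or an ether chain like 2-methoxyethyl, or a morpholine in place of the ring that carries the methyl, would move the half-life beyond the scatter.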